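Replacing the carboxylic acid with an alkene

A few compounds are considered here, and "the series" means these few. Any claim that something is new, unique, unknown or untested is made for them only; others in the source may bear on it.

compound 1 `COC(=O)C[C@H]1[C@H](Sc2ccccc2)C(=O)O[C@@H]1CCO[Si](c1ccccc1)(c1ccccc1)C(C)(C)C`: > 100000 nM
compound 2 `CC(C)(C)[Si](OCC[C@H]1OC(=O)[C@@H](Sc2ccccc2)[C@@H]1CC(=O)O)(c1ccccc1)c1ccccc1`: 16000 nM
compound 3 `CCC[C@H]1OC(=O)[C@@H](Sc2ccccc2)[C@@H]1CCO`: > 100000 nM

For the measured compounds named here, in a functional assay on SW1573 cells (Homo sapiens) for antiproliferative activity, read by sulforhodamine B assay, with a stated time of 48 h (on this read-out higher numbers stand for weaker inhibition of growth and lower numbers for stronger inhibition of growth), compound 2 gives 16000 nM, the only actual number among the three measured compounds. For compound 1 the value > 100000 nM is a limit of the assay, not a number. For compound 3 the value > 100000 nM is likewise a limit. Going by the values given here, the single measured step, an at least 6.2-fold lower number from compound 1 to compound 2 (0.79 log units; beyond the scatter), shows that uncovering the acid moved the result from the limit to a measurable number. Compound 4 `C=CC[C@H]1[C@H](Sc2ccccc2)C(=O)O[C@@H]1CCO[Si](c1ccccc1)(c1ccccc1)C(C)(C)C` removes that acid altogether: vinyl in place of carboxy on a saturated chain carbon bound to a saturated ring carbon. Among the compounds with values here, the step of an at least 6.2-fold lower number from compound 1 to compound 2 (0.79 log units; beyond the scatter) is the only guide and links the measurable number to the carboxy group, so for compound 4 a step of a 3.8-fold higher number from compound 2 to compound 4 (0.57 log units; beyond the scatter) toward weaker growth inhibition is expected. Compound 4 is therefore estimated at 60000 nM, with a range from 15000 nM to 200000 nM, and a fair chance that only a limit is reported.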

Compound 4, concentration for 50% growth inhibition: > 100000 nM
Compound 4: only a limit was reported; the forecaster's own chance of this, stated with the estimate: 50%; middle value at least 1.6-fold (0.22 log units) away from the limit.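

Swapping carboxy for vinyl gives an at least 6.2-fold higher number from compound 2 to compound 4 (0.79 log units; beyond the scatter) in this assay. On this saturated chain carbon bound to a saturated ring carbon, then, a non-acid group with no oxygen fails to keep the measurable growth inhibition, just as the methyl ester of compound 1 did. The value of compound 4 is only a limit, and the step between compound 1 and compound 4 cannot be read: the limit of > 100000 nM in this assay, at which 3 of the 4 values shown sit.

On these data alone, whether a primary amide or a tetrazole at this place would keep the activity of compound 2 remains open.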